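The compounds below may be only part of what the source reports. "The series", "measured", "known", "first", "only" and "open" are said of these compounds alone.

Measured compounds:
compound 1 `Cc1ccccc1N(C)C(=O)c1ccc(-c2ccc(O)c(Cl)c2)o1` with 52 nM in an assay on T47D cells for inhibition of 17-beta-hydroxysteroid dehydrogenase type 1 (Homo sapiens), read by HPLC, with a stated time of 24 h; on this read-out lower numbers stand for stronger inhibition and higher numbers for weaker inhibition
compound 2 `Cc1ccc(F)cc1N(C)C(=O)c1ccc(-c2ccc(O)cc2)o1` with 12 nM
compound 3 `Cc1cc(F)ccc1N(C)C(=O)c1ccc(-c2ccc(O)cc2)o1` with 7.6 nM

Compound 3 gives the lowest of the three numbers in this assay. Its nearest neighbour is compound 2, and the step of a 1.6-fold lower number from compound 2 to compound 3 (0.20 log units; within the scatter) lies within the scatter, so the two cannot be ordered. Within the data shown here, compound 1 differs from compound 3 in two places and no single step is available; its number is simply the highest of the three.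

Compound 4 `Cc1ncccc1N(C)C(=O)c1ccc(-c2ccc(O)cc2)o1` has not yet been measured in this assay. It differs from compound 3 by 2-methylpyridin-3-yl in place of 4-fluoro-2-methylphenyl on an amide-type nitrogen. Among the measured compounds shown here, no measured step exchanges a phenyl for a pyridinyl at this position; the only single-place step, from compound 2 to compound 3, moves a fluorine around the same ring and stays within the scatter. Thus the expectation for compound 4 rests on little, and a modest weakening of a 2.0-fold higher number from compound 3 to compound 4 (0.30 log units; within the scatter) is estimated. Compound 4 is expected to give about 15 nM in this assay, within a range of 4 nM to 60 nM.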

Compound 4, half-maximal inhibitory concentration: 43 nM
Compound 4: the middle estimate sits 2.9-fold (0.46 log units) below what was measured; the measured number falls inside the stated range.
By their numbers in this assay, from the lowest: compounds 3 and 2 (each within the scatter of the next); then compounds 4 and 1 (each within the scatter of the next).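

The change to 2-methylpyridin-3-yl in this assay gives a 5.7-fold higher number from compound 3 to compound 4 (0.75 log units; beyond the scatter) and a 3.6-fold higher number from compound 2 to compound 4 (0.55 log units; beyond the scatter), and both steps lie beyond the scatter. The ring on the amide-type nitrogen is therefore not indifferent to every exchange, although the earlier pair, which differs only in where the fluorine stands, gave no step beyond the scatter. Nothing available bears on why the number rises with this change.

The change removes the fluorine and brings in the ring nitrogen together, so the compounds shown cannot separate the two. Also open, from the compounds shown here alone, is how a fluorine-bearing 2-methylpyridin-3-yl, or a ring with a methoxy group in place of the methyl, would behave at this place.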